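A few compounds are considered here, and "the series" means these few. Any claim that something is new, unique, unknown or untested is made for them only; others in the source may bear on it.

Measured compounds in a functional assay on HCT-116 cells (Homo sapiens) for antiproliferative activity; on this read-out lower numbers stand for stronger inhibition and higher numbers for weaker inhibition:
compound 1, `Nc1nc(Nc2ccc(S(=O)(=O)NC(=O)CCC(=O)O)cc2)nn1C(=O)c1c(F)cccc1F`: > 100000 nM
compound 2, `NCC(=O)NS(=O)(=O)c1ccc(Nc2nc(N)n(C(=O)c3c(F)cccc3F)n2)cc1`: 36900 nM

For the measured compounds named here, compound 2 gives 36900 nM in this assay, the only number among the two values shown. For compound 1 the value > 100000 nM is a limit of the assay, not a number (the limit of > 100000 nM in this assay, at which 1 of the 2 values shown sits). Going by the values given here, the one measured step, an at least 2.7-fold lower number from compound 1 to compound 2 (0.43 log units; beyond the scatter), runs from that limit to the number of compound 2. Compound 3, `COCCOCC(=O)NS(=O)(=O)c1ccc(Nc2nc(N)n(C(=O)c3c(F)cccc3F)n2)cc1`, differs from compound 2 by 2-methoxyethoxy in place of amino on a saturated chain carbon bound to a carbonyl carbon. Among the compounds with values here, no measured step touches a 2-methoxyethoxy group, and the only step at the same place starts from a limit, so its size is bounded on one side only. The expectation for compound 3 is accordingly loose: a step of a 1.4-fold higher number from compound 2 to compound 3 (0.13 log units; within the scatter) is expected, within the scatter or towards a higher number, with a real chance that this assay returns only a limit. Compound 3 is expected at 50000 nM, range 15000 nM to 150000 nM.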

Compound 3, half-maximal inhibitory concentration: > 10000 nM
Compound 3: a limit, no number; the forecaster's own chance of this, stated with the estimate: 40%; the middle value is on the limit's open side.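

In this assay compound 3 gives > 10000 nM, which is a limit and not a number. For the compounds shown here, no step from compound 1 or compound 2 to compound 3 can be read. The compounds shown leave open how 2-methoxyethoxy in place of amino changes the number in this assay.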